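Solubility step from a tert-butyl to a hydroxy group

The source may report more compounds than this note shows. Statements on the series, on what has been measured and on what is new or still open speak of the compounds shown alone.

Measured compounds:
compound 1 `Cc1cc(NC(=O)Nc2ccc(C(C)(C)C)cc2)c2ccccc2n1` — 6200 nM
compound 2 `COc1ccc(NC(=O)Nc2cc(C)nc3ccccc23)cc1OC` — 4100 nM
compound 3 `Cc1cc(NC(=O)Nc2cccc3nsnc23)c2ccccc2n1` — 300 nM

Of the compounds shown here, three sharing one core have been measured in a physicochemical assay for solubility, at pH 7.4; on this read-out lower numbers stand for lower solubility and higher numbers for higher solubility. Compound 1 gives the highest of the three numbers, 6200 nM, and compound 2 sits nearest to it with 4100 nM, a gap that lies within the scatter of the method. Compound 3 stands furthest away with 300 nM, a gap beyond the scatter. For the measured compounds named here, no pair of these three differs in only one place, so no single step can be read from them.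

Compound 4 `Cc1cc(NC(=O)Nc2ccc(O)cc2)c2ccccc2n1` has not yet been measured in this assay. It differs from compound 1 in one place: hydroxy in place of tert-butyl on an aromatic carbon. Because compound 1 already gives 6200 nM, compound 4 is expected to move upward by a step of a 2.4-fold higher number from compound 1 to compound 4 (0.38 log units; beyond the scatter), a step larger than the scatter. On this basis compound 4 is estimated at 15000 nM, with a range from 4000 nM to 60000 nM.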

Compound 4, solubility: 100 nM
Compound 4: the middle estimate sits 150-fold (2.18 log units) above what was measured; measured number below the stated range.
By their numbers in this assay, from the lowest: compound 4; then compound 3; then compounds 2 and 1 (each within the scatter of the next).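

Hydroxy in place of tert-butyl on this aromatic carbon gives the only step that can be read in this assay, a 62-fold lower number from compound 1 to compound 4 (1.79 log units; beyond the scatter), and it shows that the read-out depends strongly on what this position carries. The number falls even though the group that enters has a hydrogen-bond donor and a hydrogen-bond acceptor and the group that leaves has neither. Nothing measured here accounts for the size or direction of this step.

With the rest of compound 1 unchanged, the compounds shown hold only tert-butyl and hydroxy at this position, so it stays open whether the fall belongs to hydroxy itself or to the loss of tert-butyl. An amine, a carboxylic acid or a longer chain on the same aromatic carbon would help to separate these two readings.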